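The compounds below may be only part of what the source reports. "The series", "measured", "known", "first", "only" and "open" are said of these compounds alone.

In an ADME assay on microsomes from liver (Homo sapiens) for metabolic stability, read by LC-MS, with a stated time of 30 min, tested at 0.5 uM (a lower number here means that less of the compound is left, a higher number that more of the compound is left), compound 1 `Oc1cccc(-c2nc(-c3csc(N=C4NCCCN4)n3)cs2)c1` gives 77% and compound 2 `Oc1ccccc1-c1nc(-c2csc(N=C3NCCCN3)n2)cs1` gives 30%, so compound 2 holds the lower of the two numbers. Compound 3 `c1cncc(-c2nc(-c3csc(N=C4NCCCN4)n3)cs2)c1` keeps the shared core and changes one group: pyridin-3-yl takes the place of 2-hydroxyphenyl on an aromatic carbon of the five-membered aromatic ring with 1 nitrogen and 1 sulfur (pyridin-3-yl in place of 2-hydroxyphenyl on an aromatic carbon). For the measured compounds named here, only one measured step bears on this place, a number 47 percentage points lower from compound 1 to compound 2 (beyond the scatter), which is large and beyond the usual scatter. Going by the values given here, it shows that swapping one group here can move the number a long way, but no compound with pyridin-3-yl has been measured yet. Among the compounds with values here, since the low number so far belongs to the 2-hydroxyphenyl group, a rise of similar scale, somewhat smaller, is expected. The estimated step is a number 30 percentage points higher from compound 2 to compound 3 (beyond the scatter). Compound 3 is estimated at 60%, with an expected range from 35% to 85%.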

Compound 3, percent of the compound remaining: 78%
Estimate against measurement, compound 3: 18 percentage points below; low and high end bracket the measured number.
By their numbers in this assay, from the lowest: compound 2; then compounds 1 and 3 (each within the scatter of the next).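

In this assay, pyridin-3-yl in place of 2-hydroxyphenyl gives a number 48 percentage points higher from compound 2 to compound 3 (beyond the scatter) on this aromatic carbon of the five-membered ring. The low number of compound 2 therefore does not hold for every group placed here, and a ring without a hydroxyl can carry a high number at this place. Pyridin-3-yl in place of 3-hydroxyphenyl gives a number 1 percentage points higher from compound 1 to compound 3 (within the scatter) and so cannot be told apart from the 3-hydroxyphenyl group in this read-out, while nothing at hand explains why the 2-hydroxyphenyl group stands apart.

As far as these compounds go, it stays open whether a phenyl ring carrying a methoxy group or an amine in place of the hydroxyl would sit near compound 2 or near compound 3. From the compounds shown here alone, a plain phenyl ring is equally open.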